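The source may hold more compounds than are shown below. What is called first, only, known or untested is meant among the compounds shown, and "the series" means these compounds.

Measured compounds in an ADME assay on a cell-free system (plasma, Mus musculus) for protein binding; on this read-out lower numbers stand for a smaller free fraction and higher numbers for a larger free fraction:
compound 1 `CS(=O)(=O)N1CCC(C(=O)N2CC[C@](c3ccc(C(F)(C(F)(F)F)C(F)(F)F)cc3)(S(=O)(=O)c3ccc(F)cc3)C2)CC1`: "not determined" (no result reported)
compound 2 `O=C(O)C1CCN(C(=O)N2CC[C@](c3ccc(C(F)(C(F)(F)F)C(F)(F)F)cc3)(S(=O)(=O)c3ccc(F)cc3)C2)CC1`: "not determined" (no result reported)
compound 3 `Cc1ccc(S(=O)(=O)[C@@]2(c3ccc(C(F)(C(F)(F)F)C(F)(F)F)cc3)CCN(C(=O)[C@H]3CC[C@H](C(=O)O)CC3)C2)cc1`: 0.026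

Of these three, only compound 3 has a number, 0.026, so it cannot be ranked against compound 1 or compound 2, neither of which has a reported result. Compound 4 `Cc1cc(S(=O)(=O)[C@@]2(c3ccc(C(F)(C(F)(F)F)C(F)(F)F)cc3)CCN(C(=O)[C@H]3CC[C@H](C(=O)O)CC3)C2)ccc1F` has not yet been measured. It differs from compound 3 in one place, with 4-fluoro-3-methylphenyl in place of 4-methylphenyl on a sulfonyl sulfur.

Among the compounds with values here, no measured pair shows what such a change does in this assay, so the expectation rests on the single value of compound 3 at 0.026 and on the modest size of the change. No shift beyond the usual scatter is expected, with only a slight lean toward a smaller free fraction. The expected move is a 1.2-fold lower number from compound 3 to compound 4 (0.07 log units; within the scatter). For compound 4 the estimated value is 0.022, within an expected range of 0.012 to 0.042.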

Compound 4, unbound fraction: 0.029
Compound 4: the middle estimate sits 1.3-fold (0.12 log units) below what was measured; low and high end bracket the measured number.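

In this assay, within the data shown here, the change from 4-methylphenyl to 4-fluoro-3-methylphenyl on a sulfonyl sulfur gives a 1.1-fold higher number from compound 3 to compound 4 (0.05 log units; within the scatter), the first step that can be read at this position. The added fluorine, one more heavy atom on the aromatic ring, therefore leaves compound 4 indistinguishable from compound 3 on this read-out, and the free fraction of this pair gives no sign of depending on this difference. No measured evidence bears on why the two compounds match.

On these data alone, this single pair sets no pattern, and it remains open whether the change would behave the same way with a different group on the rest of the shared core. It also leaves open whether a nitrile or an amine on that aromatic ring would produce a step beyond the scatter.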